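Swapping the Amide Cap for a Sulfonamide on Compound 2

A few compounds are considered here, and "the series" means these few. Any claim that something is new, unique, unknown or untested is made for them only; others in the source may bear on it.

Measured so far:
- compound 1 `O=C(Nc1ncc(C(Oc2ccc3cc(Br)ccc3c2)c2ccc(Cl)cc2)s1)c1ccccc1`: "not toxic" (no number reported)
- compound 2 `O=C(Nc1ncc(C(Oc2ccc3cc(Br)ccc3c2)c2ccc(Cl)cc2)s1)c1ccc(Br)cc1`: > 50000 nM

In an ADME assay on HepG2 2.2.15 cells (Homo sapiens) for cytotoxicity (a higher number here means that more compound is tolerated, a lower number that less compound is tolerated), compound 2 reaches only a limit, > 50000 nM, and not a number. For compound 1 the outcome is given in words alone, "not toxic" (no number reported). Within the data shown here, this is the one place where compound 2 stands: at the limit of this assay, (the limit of > 50000 nM in this assay, at which 1 of the 2 values shown sits), with no neighbouring compound that differs from it in a single spot, so no measured step is known.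

Compound 3 `O=S(=O)(Nc1ncc(C(Oc2ccc3cc(Br)ccc3c2)c2ccc(Cl)cc2)s1)c1cccc2nsnc12` is the untested member. Compared with compound 2, the change is a group of 12 heavy atoms (6 carbon, 2 nitrogen, 2 oxygen, 2 sulfur; one five-membered aromatic ring with 3 hetero atoms, one six-membered aromatic ring of carbon only) in place of a group of 9 heavy atoms (7 carbon, 1 oxygen, 1 bromine; one six-membered aromatic ring of carbon only), on a nitrogen on an aromatic ring.

Among the measured compounds shown here, with no measured step to lean on, the expectation rests on the two outcomes seen so far. Both compound 1 and compound 2 are tolerated up to what this assay can report, so for compound 3 a step of a number no higher from compound 2 to compound 3 (the limit leaves the size open) is expected, that is, none beyond the scatter. Compound 3 is therefore estimated at 50000 nM, within a range of 15000 nM to 150000 nM, most likely again reported as a limit.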

Compound 3, half-maximal cytotoxic concentration: "not toxic" (no number reported)
Compound 3: no number reported; there is nothing to compare the estimate with.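

Among these compounds, no step from compound 2 to compound 3 can be read: in this assay compound 3 has a result in words and no number, and compound 2 has only a limit. The compounds shown leave open at what concentration any of them would harm these cells, and whether replacing the (4-bromophenyl)carbonyl group changes that concentration.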